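Working notes: aryl swap from compound 1 to compound 4

The source may report more compounds than this note shows. Statements on the series, on what has been measured and on what is new or still open speak of the compounds shown alone.

Measured so far:
compound 1, `COc1ccc(-c2nc3c(NC4CCCC4)ncnc3n2C)cc1`, > 30000 nM
compound 2, `CCCn1c(-c2ccccc2)nc2c(NC3CCCC3)ncnc21`, 3430 nM
compound 3, `CCCn1c(-c2ccccc2)nc2c(NC3CCCCC3)ncnc21`, 5310 nM

In a functional assay on CHO cells for antagonist activity at adenosine receptor A2b (Homo sapiens), read by 33P incorporation, with a stated time of 20 min (a higher number here means a weaker inhibitor, a lower number a stronger inhibitor), compound 1 gives only a limit, > 30000 nM, which is the limit of > 30000 nM in this assay, at which 1 of the 3 values shown sits. Compound 2 gives 3430 nM and compound 3 gives 5310 nM; between them, a 1.5-fold higher number from compound 2 to compound 3 (0.19 log units; within the scatter).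

Compound 4, `Cc1ccccc1-c1nc2c(NC3CCCC3)ncnc2n1C`, differs from compound 1 by 2-methylphenyl in place of 4-methoxyphenyl on an aromatic carbon. Among the measured compounds shown here, no measured step touches this aryl group; the one measured step concerns the amine ring and stays within the scatter, so it gives no direction for the change here. For the measured compounds named here, compounds 2 and 3, carrying an unsubstituted phenyl and a propyl group, are the only members with numbers rather than a limit, and compound 4 keeps the methyl of compound 1. Compound 4 is therefore expected to remain weak, estimated at 20000 nM (range 6000 nM to 60000 nM), an expected step of an at least 1.5-fold lower number from compound 1 to compound 4 (0.17 log units; that floor lies within the scatter).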

Compound 4, inhibition constant: > 30000 nM
Compound 4 was reported as a limit; the forecaster's own chance of this, stated with the estimate: 50%; middle value at least 1.5-fold (0.17 log units) away from the limit.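

Compound 1 and compound 4 are both reported as limits rather than numbers, so no step between them can be read: the limit of > 30000 nM in this assay, at which 2 of the 4 values shown sit.

The compounds shown leave open whether 2-methylphenyl and 4-methoxyphenyl differ at all on this shared core.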